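The source may report more compounds than this note shows. Statements on the series, on what has been measured and on what is new or still open speak of the compounds shown alone.

Of the compounds shown here, three built on one shared core have been tested for cytotoxicity. In an ADME assay on L6 cells (Rattus norvegicus) for cytotoxicity (on this read-out lower numbers stand for stronger inhibition and higher numbers for weaker inhibition), compound 1 `O=C(NCCCN1CCN(CCCNc2ccnc3cc(Cl)ccc23)CC1)c1cccc(OC(F)(F)F)c1` gives 8500 nM, compound 2 `CC(=O)CCC(=O)NCCCN1CCN(CCCNc2ccnc3cc(Cl)ccc23)CC1` gives 11000 nM, and compound 3 `O=C(NCCCN1CCN(CCCNc2ccnc3cc(Cl)ccc23)CC1)c1ccc(F)c(F)c1` gives 10000 nM. Compound 3 stands close to both of the others on these numbers: its step from compound 1 reads a 1.2-fold higher number from compound 1 to compound 3 (0.07 log units; within the scatter), and its step from compound 2 reads a 1.1-fold lower number from compound 2 to compound 3 (0.04 log units; within the scatter), so neither separates it from them.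

Compound 4 `O=C(NCCCN1CCN(CCCNc2ccnc3cc(Cl)ccc23)CC1)c1cc(Cl)cc(Cl)c1` differs from compound 3 in one place: 3,5-dichlorophenyl in place of 3,4-difluorophenyl on a carbonyl carbon. Within the data shown here, every measured step so far also exchanges the group sitting on that carbonyl carbon, and each of them stayed inside the scatter, among them a 1.3-fold higher number from compound 1 to compound 2 (0.11 log units; within the scatter) as well as the two steps already named. Among the measured compounds shown here, nothing among the measured compounds points to a swing for a further exchange at this position. The step from compound 3 to compound 4 is therefore expected to be a 1.1-fold lower number from compound 3 to compound 4 (0.02 log units; within the scatter), that is, no change beyond the scatter. For compound 4 the estimated value in this assay is 9500 nM, with a range from 4500 nM to 20000 nM.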

Compound 4, half-maximal inhibitory concentration: 3000 nM
Beside the measured number, compound 4's estimate is 3.2-fold (0.50 log units) above it; measured number below the stated range.
By their numbers in this assay, from the lowest: compound 4; then compounds 1, 3 and 2 (each within the scatter of the next).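

In this assay the group on this carbonyl carbon can move the number beyond the scatter, as shown by a 3.3-fold lower number from compound 3 to compound 4 (0.52 log units; beyond the scatter). That step exchanges 3,4-difluorophenyl for 3,5-dichlorophenyl, two groups with the same heavy-atom count, and the separation also appears in a 3.7-fold lower number from compound 2 to compound 4 (0.56 log units; beyond the scatter) and in a 2.8-fold lower number from compound 1 to compound 4 (0.45 log units; beyond the scatter), all of them modest in size. No supporting information on the cause of this shift is available here.

The exchange alters both the halogen and the names of the ring positions that carry it, so the compounds shown leave open which of the two goes with the lower number; 3,4-dichlorophenyl and 3,5-difluorophenyl would pull these apart. On these data alone, it is also open how the number would respond to a phenyl ring carrying an amine or a carboxylic acid at this position.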